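A few compounds are considered here, and "the series" means these few. Any claim that something is new, unique, unknown or untested is made for them only; others in the source may bear on it.

Measured so far:
compound 1, `C=C(CC)C(=O)c1ccc(OCC(=O)NCCO)c(Cl)c1Cl` — > 25000 nM
compound 2, `C=C(CC)C(=O)c1ccc(OCC(=O)Nc2ccc3nc[nH]c3c2)c(Cl)c1Cl` — 3200 nM
compound 3, `C=C(CC)C(=O)c1ccc(OCC(=O)Nc2ccc(O)cc2)c(Cl)c1Cl` — 6400 nM

In a functional assay on CLL cells (Homo sapiens) for cytotoxicity, read by MTT assay, with a stated time of 48 h (on this read-out higher numbers stand for an effect only at larger amounts of compound and lower numbers for an effect already at smaller amounts), compound 1 gives only a limit of the assay, > 25000 nM; no number is known for it, and the limit of > 25000 nM in this assay, at which 1 of the 3 values shown sits, is the only thing that places it. Both aromatic amides lie clearly inside the measured range: an at least 7.8-fold lower number from compound 1 to compound 2 (0.89 log units; beyond the scatter) and an at least 3.9-fold lower number from compound 1 to compound 3 (0.59 log units; beyond the scatter). Between the two aromatic amides, a 2.0-fold higher number from compound 2 to compound 3 (0.30 log units; within the scatter), so compounds 2 and 3 cannot be ordered.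

Compound 4, `C=C(CC)C(=O)c1ccc(OCC(=O)NCC2CCC(C(=O)O)CC2)c(Cl)c1Cl`, differs from compound 1 by 4-carboxycyclohexyl in place of hydroxymethyl on a saturated chain carbon bound to an amide-type nitrogen. Going by the values given here, the only measured steps out of compound 1 replace the 2-hydroxyethyl chain with aromatic rings, whereas compound 4 keeps a saturated chain carbon on the amide-type nitrogen and adds a six-membered non-aromatic ring with a carboxylic acid; those steps therefore bear on it only loosely. A lowering of the number that is smaller than the aromatic steps, or none beyond the scatter, is expected. Compound 4 is expected near 15000 nM, within 5000 nM to 40000 nM. The expected step is an at least 1.6-fold lower number from compound 1 to compound 4 (0.22 log units; that floor lies within the scatter).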

Compound 4, half-maximal effective concentration: 8000 nM
Beside the measured number, compound 4's estimate is 1.9-fold (0.27 log units) above it, within the range that was stated.
By their numbers in this assay, from the lowest: compounds 2, 3 and 4 (each within the scatter of the next, the first and the last beyond it). At a limit, above all of these: compound 1.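

In this assay, an aromatic ring on the amide-type nitrogen is not required for a value inside the measured range: with a saturated chain carbon kept at this place, 4-carboxycyclohexyl in place of hydroxymethyl gives an at least 3.1-fold lower number from compound 1 to compound 4 (0.49 log units; beyond the scatter). The change adds a six-membered non-aromatic ring and a carboxylic acid, so the earlier picture, in which only the aromatic amides compound 2 and compound 3 gave measured numbers, does not hold for the series. The size of the step is only a floor, because the value of compound 1 is a limit: the limit of > 25000 nM in this assay, at which 1 of the 4 values shown sits.

The compounds shown do not separate the contribution of the ring from that of the carboxylic acid, as a plain cyclohexyl group or a primary amide in place of the acid would. As far as these compounds go, the effect of an amine on the same ring, or of a longer chain on the amide-type nitrogen, also stays open.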